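The compounds below may be only part of what the source reports. "The series", "measured", "known", "first", "only" and "open" are said of these compounds alone.

Going by the values given here, compound 2 `O=C(Nc1ccc(Cl)c(-c2nnc3c(Cl)cccn23)c1)c1cccc(Cl)c1` gives 54800 nM in a functional assay on MDA-MB-468 cells (Homo sapiens) for antiproliferative activity, read by MTT assay, with a stated time of 72 h; a higher number here means a weaker inhibitor, a lower number a stronger inhibitor; it holds the higher of the two numbers so far, compound 1 `O=C(Nc1ccc(Cl)c(-c2nnc3c(Cl)cccn23)c1)c1ccc(C(F)(F)F)cc1F` giving 22300 nM in this assay. Compound 3 `CS(=O)(=O)c1ccc(C(=O)Nc2ccc(Cl)c(-c3nnc4c(Cl)cccn34)c2)cc1` gives only a limit, > 100000 nM, in this assay, and the step of an at least 1.8-fold higher number from compound 2 to compound 3 (0.26 log units; that floor lies within the scatter) is therefore bounded by the limit of > 100000 nM in this assay, at which 1 of the 3 values shown sits, rather than by a number. Compound 4 `O=C(Nc1ccc(Cl)c(-c2nnc3c(Cl)cccn23)c1)c1ccccc1` differs from compound 2 by hydrogen in place of chloro on an aromatic carbon. Among the compounds with values here, no measured step removes a substituent on this ring, and the only step that starts from compound 2 gives a floor within the scatter, so no movement beyond the scatter is expected, with a slight lean to a higher number: compound 4 is expected at 60000 nM (range 25000 nM to 150000 nM), an estimated step of a 1.1-fold higher number from compound 2 to compound 4 (0.04 log units; within the scatter).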

Compound 4, half-maximal inhibitory concentration: > 100000 nM
Compound 4: no number, only a limit (the forecaster's own chance of this, stated with the estimate: 25%); middle value at least 1.6-fold (0.22 log units) away from the limit.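

In this assay, hydrogen in place of chloro gives an at least 1.8-fold higher number from compound 2 to compound 4 (0.26 log units; that floor lies within the scatter), so this position now has a step of its own, but only a floor that does not separate phenyl from 3-chlorophenyl. Compound 4 gives only a limit, > 100000 nM. The step between compound 3 and compound 4 cannot be read, and the unsubstituted phenyl now sits at the same limit as the 4-(methylsulfonyl)phenyl: the limit of > 100000 nM in this assay, at which 2 of the 4 values shown sit.

Open, on these data alone, is whether a methoxy group or an amine in place of this chloro would move the number beyond the scatter from compound 2.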